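The source may report more compounds than this note shows. Statements on the series, on what has been measured and on what is new or still open speak of the compounds shown alone.

Compound 1 `C=C(C)CCOC(=O)C[C@@H]1C(C(=O)OC)=CO[C@@H](O[C@@H]2O[C@H](CO)[C@@H](O)[C@H](O)[C@H]2O)/C1=C/C` was tested in a functional assay on SK-BR-3 cells (Homo sapiens) for antiproliferative activity, read by MTT assay, with a stated time of 72 h; on this read-out lower numbers stand for stronger inhibition and higher numbers for weaker inhibition. In this assay compound 1 gives > 15000 nM, which is a limit of the assay rather than a number. Compound 2 `C/C=C1/[C@H](O[C@@H]2O[C@H](COC(C)=O)[C@@H](OC(C)=O)[C@H](OC(C)=O)[C@H]2OC(C)=O)OC=C(C(=O)OC)[C@H]1CC(=O)SCCC` and compound 3 `C/C=C1/[C@H](O[C@@H]2O[C@H](COC(C)=O)[C@@H](OC(C)=O)[C@H](OC(C)=O)[C@H]2OC(C)=O)OC=C(C(=O)OC)[C@H]1CC(=O)OC` share the core of compound 1 but carry an acetylated sugar. In this assay compound 2 gives > 15000 nM, again a limit. In this assay compound 3 gives > 15000 nM, also a limit. Going by the values given here, the only change between measured compounds, methoxy in place of propylsulfanyl on a carbonyl carbon, is a step that the two limits leave unreadable from compound 2 to compound 3; the whole set sits at the limit of > 15000 nM in this assay, at which 3 of the 3 values shown sit. Compound 4 `C/C=C1/[C@H](O[C@@H]2O[C@H](CO)[C@@H](O)[C@H](O)[C@H]2O)OC=C(C(=O)OC)[C@H]1CC(=O)OCCc1ccc([N+](=O)[O-])cc1` differs from compound 1 by 4-nitrophenyl in place of 1-methylethenyl on a saturated chain carbon, two bonds along the chain from an oxygen next to a carbonyl group. Among the compounds with values here, no measured step covers this change, and none of the measured values offers a number from which to move. The step is therefore expected to be a number no higher from compound 1 to compound 4 (the limit leaves the size open). Compound 4 will most likely remain at the limit as well. Compound 4 is estimated to give 15000 nM in this assay, within 3000 nM to 50000 nM.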

Compound 4, half-maximal inhibitory concentration: > 20000 nM
Compound 4: a limit, no number (the forecaster's own chance of this, stated with the estimate: 80%); at least 1.3-fold (0.12 log units) between middle value and limit.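

Compound 1 and compound 4 both stand at limits of the assay rather than at numbers, so no step can be read between them. The compounds shown leave open the size of every change among them, and whether any such change would yield a measurable number.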